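Fluoro removal on the fused ring of compound 2

The compounds below may be only part of what the source reports. "The series", "measured", "known", "first", "only" and "open" are said of these compounds alone.

Compound 1 `Cc1cnc(Nc2ccc(Cl)cc2)nc1Nc1nc2ccccc2s1` sits at the edge of a functional assay on HeLa cells (Homo sapiens) for antiproliferative activity, read by MTT assay, with a stated time of 48 h; a lower number here means a stronger inhibitor, a higher number a weaker inhibitor: in this assay compound 1 gives > 50000 nM, a limit of the measurement rather than a number. Going by the values given here, compound 2 `NS(=O)(=O)c1ccc(Nc2nccc(Nc3nc4ccc(F)cc4s3)n2)cc1` is the only member with a number: in this assay compound 2 gives 450 nM. Among the compounds with values here, compounds 1 and 2 differ in more than one place, so no single step between them can be read; the two values show only that one sits at the limit of > 50000 nM in this assay, at which 1 of the 2 values shown sits, and the other gives a number. Compound 3 `NS(=O)(=O)c1ccc(Nc2nccc(Nc3nc4ccccc4s3)n2)cc1` is not yet measured. It differs from compound 2 in one place: hydrogen in place of fluoro on an aromatic carbon. The change removes a single fluorine and nothing else. Within the data shown here, no measured step resembles it, so no direction can be taken from the numbers; a step from compound 2 to compound 3 within the usual scatter is expected in this assay, in no fixed direction. The value of compound 3 in this assay is estimated at 550 nM, between 200 nM and 1600 nM. That corresponds to an expected step of a 1.2-fold higher number from compound 2 to compound 3 (0.09 log units; within the scatter).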

Compound 3, half-maximal inhibitory concentration: 2060 nM
Compound 3: the middle estimate sits 3.7-fold (0.57 log units) below what was measured; the measured number lies above the stated range.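

In this assay, going by these compounds alone, hydrogen in place of fluoro on this aromatic carbon gives a 4.6-fold higher number from compound 2 to compound 3 (0.66 log units; beyond the scatter), the first step that can be read at a single place. It shows that this position is not indifferent to what it carries: the loss of 1 heavy atom, with no ring, no hydrogen-bond donor or acceptor and no net charge involved, is enough to move the number beyond the scatter, and of this pair compound 2, with fluoro, is the stronger. Nothing measured for these compounds gives a reason for the step.

Within the data shown here, compound 1 differs from compound 2 and from compound 3 in more than one place, so no step to either can be read. Going by these compounds, whether fluoro itself matters, or any group on this carbon would serve, stays open, since a single pair cannot separate the two; a chloro group, a methoxy group or a nitrile at the same place would bear on that, and the same swap elsewhere on the ring remains equally unknown.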